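This account rests on a few compounds, and the source may have more. Where it says the series, first, only, none or still open, it means among the compounds named here.

Measured so far:
compound 1 `COc1cc(NC(C)CCCNC(=O)Nc2cccc(F)c2)c2ncccc2c1` — in a functional assay on MCF7 cells (Homo sapiens) for inhibition, read by MTT assay, with a stated time of 72 h (on this read-out higher numbers stand for weaker inhibition and lower numbers for stronger inhibition), compound 1 gives 18000 nM
compound 2 `COc1cc(NC(C)CCCNC(=O)NNC(=O)Nc2ccc(C(F)(F)F)cc2)c2ncccc2c1` — in this assay compound 2 gives 100 nM

Compound 2 holds the lower of the two numbers; compound 1 stands far above it, well beyond the scatter. The two differ in more than one place, so the gap between them is read only as what the two values show, not as a single structural step.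

Compound 3 `COc1cc(NC(C)CCCNC(=O)NNC(=O)Nc2ccc(O)cc2)c2ncccc2c1` has not yet been measured. It differs from compound 2 in one place: hydroxy in place of trifluoromethyl on an aromatic carbon. Among the measured compounds shown here, no measured pair here carries a change of this kind, so there is no directly comparable step to lean on. Compound 3 is expected to give a somewhat higher number than compound 2, with a 3.0-fold higher number from compound 2 to compound 3 (0.48 log units; beyond the scatter) as a modest expected shift, and the range is kept wide enough to include no change beyond the scatter. The estimate for compound 3 in this assay is 300 nM, expected between 60 nM and 2000 nM.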

Compound 3, half-maximal inhibitory concentration: 2600 nM
Beside the measured number, compound 3's estimate is 8.7-fold (0.94 log units) below it; the whole stated range lies below it.
By their numbers in this assay, from the lowest: compound 2; then compound 3; then compound 1.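

Working notes: in this assay, the aromatic carbon para to a large group proves sensitive, the first single-place reading at this position: hydroxy in place of trifluoromethyl gives a 26-fold higher number from compound 2 to compound 3 (1.41 log units; beyond the scatter), a large step. Even with hydroxy on this carbon, ((4-hydroxyphenyl)carbamoyl)amino in place of 3-fluorophenyl on an amide-type nitrogen gives a 6.9-fold lower number from compound 1 to compound 3 (0.84 log units; beyond the scatter), so the change at that nitrogen still reads as a modest gain while the ring substituent sets much of the remaining level. No measured property of these compounds bears on the result, and the values alone offer no explanation for it.

Open, on these data alone, is whether the step follows from the loss of trifluoromethyl or the arrival of hydroxy; a chlorine atom or an amine on the same aromatic carbon would help separate the two. Also open, as far as these compounds go, is how a 3-fluorophenyl group would behave on the longer chain of compound 3.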